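The source may report more compounds than this note shows. Statements on the series, on what has been measured and on what is new or still open speak of the compounds shown alone.

Compound 1 `COc1ccc(CN(C(=O)Cn2cc(COc3cc(=O)oc4ccccc34)nn2)c2cc(OC)c(OC)c(OC)c2)cc1` gives the lowest number of the three measured compounds in a functional assay on HepG2 cells (Homo sapiens) for antiproliferative activity, read by MTT assay, with a stated time of 48 h (a lower number here means a stronger inhibitor, a higher number a weaker inhibitor), at 6250 nM. Compound 2 `COc1ccc(CN(C(=O)Cn2cc(CSc3nc4ccccc4o3)nn2)c2cc(OC)c(OC)c(OC)c2)cc1` gives 15600 nM and compound 3 `COc1ccc(CN(C(=O)Cn2cc(CNS(=O)(=O)c3ccc(C)cc3)nn2)c2cc(OC)c(OC)c(OC)c2)cc1` gives 30500 nM; the step of a 2.5-fold higher number from compound 1 to compound 2 (0.40 log units; beyond the scatter) and the step of a 4.9-fold higher number from compound 1 to compound 3 (0.69 log units; beyond the scatter) both run upward, while the step of a 2.0-fold higher number from compound 2 to compound 3 (0.29 log units; within the scatter) is small. Compound 4 `COc1ccc(CN(C(=O)Cn2cc(CNS(=O)(=O)c3ccc(Br)cc3)nn2)c2cc(OC)c(OC)c(OC)c2)cc1` differs from compound 1 by a group of 11 heavy atoms (6 carbon, 1 nitrogen, 2 oxygen, 1 sulfur, 1 bromine; one six-membered aromatic ring of carbon only) in place of a group of 12 heavy atoms (9 carbon, 3 oxygen; one six-membered aromatic ring of carbon only, one six-membered aromatic ring with 1 hetero atom), on a saturated chain carbon bound to an aromatic carbon. Going by the values given here, the closest precedent is compound 3, whose sulfonylamino group differs from that of compound 4 only in the bromine in place of methyl, so the step of a 4.9-fold higher number from compound 1 to compound 3 (0.69 log units; beyond the scatter) is the guide, and compound 4 is expected to show a similar upward step, a 4.5-fold higher number from compound 1 to compound 4 (0.65 log units; beyond the scatter). Compound 4 is therefore estimated at 28000 nM, within a range from 12000 nM to 65000 nM.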

Compound 4, half-maximal inhibitory concentration: 7370 nM
The estimate for compound 4 lay 3.8-fold (0.58 log units) above the measured number; the whole stated range lies above it.
By their numbers in this assay, from the lowest: compounds 1 and 4 (each within the scatter of the next); then compounds 2 and 3 (each within the scatter of the next).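

Bromo in place of methyl on an aromatic carbon gives a 4.1-fold lower number from compound 3 to compound 4 (0.62 log units; beyond the scatter), so the sulfonylamino group alone does not fix the number; the substituent on its aromatic ring also counts. With bromo, that group gives a 1.2-fold higher number from compound 1 to compound 4 (0.07 log units; within the scatter) and a 2.1-fold lower number from compound 2 to compound 4 (0.33 log units; beyond the scatter), so ((4-bromophenyl)sulfonyl)amino matches the group of compound 1 within the scatter. Nothing shown here offers an explanation for the bromo effect. On these data alone, with only methyl and bromo compared, it remains open how chloro, nitrile or a carboxylic acid at that ring carbon would read.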